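Shifting the hydroxyl along the sulfur-linked chain

The compounds below may be only part of what the source reports. "The series", "measured", "known", "first", "only" and "open" are said of these compounds alone.

The series shares one core and varies only the group on the sulfur. Compound 1 `CC(C)c1n[nH]c2c(NCc3ccc(-c4ccccn4)cc3)nc(SCC(N)CN)nc12` carries a 1,2-diaminoethyl there, compound 2 `CC(O)CSc1nc(NCc2ccc(-c3ccccn3)cc2)c2[nH]nc(C(C)C)c2n1` a 1-hydroxyethyl, compound 3 `CSc1nc(NCc2ccc(-c3ccccn3)cc2)c2[nH]nc(C(C)C)c2n1` a hydrogen. In a functional assay on HT cells (Homo sapiens) for antiproliferative activity, read by fluorescence, with a stated time of 72 h (a higher number here means a weaker inhibitor of growth, a lower number a stronger inhibitor of growth), compound 1 gives 480 nM, compound 2 gives 62 nM and compound 3 gives 783 nM. Compound 2 stands lowest of the three, with both neighbours beyond the scatter: a 7.7-fold lower number from compound 1 to compound 2 (0.89 log units; beyond the scatter), and a 13-fold higher number from compound 2 to compound 3 (1.10 log units; beyond the scatter). Compound 1 against compound 3 differs little: a 1.6-fold higher number from compound 1 to compound 3 (0.21 log units; within the scatter).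

Compound 4 `CC(C)c1n[nH]c2c(NCc3ccc(-c4ccccn4)cc3)nc(SCCCO)nc12` keeps the same atoms as compound 2 and rearranges them: 2-hydroxyethyl in place of 1-hydroxyethyl on a saturated chain carbon bound to a sulfur. The measured steps speak only to adding or removing a group at this carbon, not to moving the hydroxyl one position along; the large loss in a 13-fold higher number from compound 2 to compound 3 (1.10 log units; beyond the scatter) shows that the hydroxyethyl as such matters in this assay, and the modest change in a 7.7-fold lower number from compound 1 to compound 2 (0.89 log units; beyond the scatter) shows that what sits on the chain changes the number. With the hydroxyl and the chain count retained, no step beyond the scatter is expected for compound 4, with a small drift either way possible. Compound 4 is therefore estimated at 90 nM in this assay, within 35 nM to 250 nM, an expected step of a 1.5-fold higher number from compound 2 to compound 4 (0.16 log units; within the scatter).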

Compound 4, concentration for 50% growth inhibition: 109 nM
Compound 4: the middle estimate sits 1.2-fold (0.08 log units) below what was measured, and the stated range covers the measured number.
By their numbers in this assay, from the lowest: compounds 2 and 4 (each within the scatter of the next); then compounds 1 and 3 (each within the scatter of the next).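

In this assay, 2-hydroxyethyl in place of 1-hydroxyethyl on a saturated chain carbon bound to a sulfur leaves the two isomers within the scatter of each other (a 1.8-fold higher number from compound 2 to compound 4 (0.25 log units; within the scatter)), so the placement of the hydroxyl on this chain does not separate them. The advantage over the other two groups also carries over to the 2-hydroxyethyl isomer, both against the hydrogen (a 7.2-fold lower number from compound 3 to compound 4 (0.86 log units; beyond the scatter)) and against the 1,2-diaminoethyl (a 4.4-fold lower number from compound 1 to compound 4 (0.64 log units; beyond the scatter)), so among these compounds it is not tied to the 1-hydroxyethyl arrangement alone. Nothing available accounts for this tolerance or for the separation from compounds 1 and 3.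

Open, on these data alone, is whether the hydroxyl itself is what counts, since a methoxy group, a single terminal amine or a carboxylic acid on the same chain could give a different reading. Also open, as far as these compounds go, is how far the chain can go, as a longer chain bearing a terminal hydroxyl or a second hydroxyl on the 3-hydroxypropyl chain would show whether this tolerance extends beyond the two isomers.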